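A few compounds are considered here, and "the series" means these few. Any claim that something is new, unique, unknown or untested is made for them only; others in the source may bear on it.

In a functional assay on MV4-11 cells (Homo sapiens) for inhibition, read by resazurin assay, with a stated time of 72 h (a higher number here means a weaker inhibitor of growth, a lower number a stronger inhibitor of growth), compound 1 `O=C1NCCC12CCN(c1c(Cl)cncc1-c1cccs1)CC2` gives 480 nM, compound 2 `Cc1ccc(-c2cncc(Cl)c2N2CCC3(CCNC3=O)CC2)o1` gives 4950 nM, and compound 3 `O=Cc1ccc(-c2cncc(Cl)c2N2CCC3(CCNC3=O)CC2)s1` gives 750 nM. Compound 3 therefore stands level with compound 1 within the scatter, shown by a 1.6-fold higher number from compound 1 to compound 3 (0.19 log units; within the scatter), and well apart from compound 2, shown by a 6.6-fold lower number from compound 2 to compound 3 (0.82 log units; beyond the scatter). Compound 4 `O=Cc1cscc1-c1cncc(Cl)c1N1CCC2(CCNC2=O)CC1` has the same atoms joined differently: 4-formylthiophen-3-yl in place of 5-formylthiophen-2-yl on an aromatic carbon. Among the measured compounds shown here, no measured step moves the formyl group or the ring attachment, so the evidence is indirect. Yet a 10-fold higher number from compound 1 to compound 2 (1.01 log units; beyond the scatter) shows that changing this aromatic group can matter greatly, while a 1.6-fold higher number from compound 1 to compound 3 (0.19 log units; within the scatter) stays small. A modest rise is therefore expected, an estimated 2.0-fold higher number from compound 3 to compound 4 (0.30 log units; within the scatter). Compound 4 is estimated at 1500 nM, with an expected range of 450 nM to 5000 nM.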

Compound 4, concentration for 50% growth inhibition: 27100 nM
For compound 4 the middle estimate is 18-fold (1.26 log units) below the measured one; the whole stated range lies below it.
By their numbers in this assay, from the lowest: compounds 1 and 3 (each within the scatter of the next); then compound 2; then compound 4.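

Swapping 5-formylthiophen-2-yl for 4-formylthiophen-3-yl keeps the same atoms yet gives a 36-fold higher number from compound 3 to compound 4 (1.56 log units; beyond the scatter) in this assay, so at this position, ortho to a large group, how the ring and its formyl group are joined matters greatly. Compound 4 is also the weakest of the set, with a 5.5-fold higher number from compound 2 to compound 4 (0.74 log units; beyond the scatter) and a 56-fold higher number from compound 1 to compound 4 (1.75 log units; beyond the scatter). No measurement shown here explains this loss. From the compounds shown here alone, the ring attachment and the formyl position change together, and their separate shares remain open. Also open, going by these compounds, is how a carboxylic acid or an amine would fare in place of the formyl group.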